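The source may hold more compounds than are shown below. What is called first, only, known or untested is meant among the compounds shown, and "the series" means these compounds.

Measured in an ADME assay on MT4 cells (Homo sapiens) for cytotoxicity, read by MTT assay; a lower number here means that less compound is tolerated, a higher number that more compound is tolerated:
Compound 1 `Cc1c(C(C)c2c(F)cccc2F)nc(N(C)C)[nH]c1=O`: > 17000 nM, a limit and not a number.
Compound 2 `Cc1c(N)nc(Nc2ccc(C#N)cc2)nc1Cc1c(F)cccc1F`: 45900 nM
Compound 3 `Cc1cnc(Nc2ccc(C#N)cc2)nc1C(C)c1c(F)cccc1F`: 71400 nM

For the measured compounds named here, compound 3 at 71400 nM lies within the scatter of compound 2 at 45900 nM, and these are the only two true numbers. Compound 4 `Cc1c(Cl)nc(Nc2ccc(C#N)cc2)nc1C(C)c1c(F)cccc1F` differs from compound 3 by chloro in place of hydrogen on an aromatic carbon, next to the ring nitrogen and ortho to a methyl group. Going by the values given here, no measured pair shows this change, so only a small shift toward a lower number is expected in this assay, not clearly beyond the scatter. The expected step is a 1.9-fold lower number from compound 3 to compound 4 (0.27 log units; within the scatter). For compound 4 the estimated value is 38000 nM, with an expected range of 12000 nM to 100000 nM.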

Compound 4, half-maximal cytotoxic concentration: > 13000 nM
Compound 4 was reported as a limit; the forecaster's own chance of this, stated with the estimate: 30%; the middle value is on the limit's open side.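

In this assay compound 4 gives > 13000 nM, a limit and not a number. For the compounds shown here, no step from compound 3 to compound 4 can therefore be read. The compounds shown leave open what size of shift chloro in place of hydrogen on an aromatic carbon brings.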